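Anticonvulsant series: aryl swap on the piperazine nitrogen

A few compounds are considered here, and "the series" means these few. Any claim that something is new, unique, unknown or untested is made for them only; others in the source may bear on it.

Working notes. Compound 1 `Cc1cccc(N2CCN(C(=O)CN3C(=O)CC(C)(c4ccccc4)C3=O)CC2)c1` carries a 3-methylphenyl on the ring nitrogen of the shared core. In a functional assay on the whole organism (strain CD-1) with Mus musculus as the target, with a stated time of 0.5 h (a higher number here means that more compound is needed for the effect, a lower number that less compound is needed), compound 1 gives "not active" (no number reported), so no single number stands for it and there is no value from which a step could be counted. Among the compounds with values here, compound 2 `CC1(c2ccccc2)CC(=O)N(CC(=O)N2CCC(Cc3ccccc3)CC2)C1=O`, which bears a different amine ring on the same amide, is the only member with a number: in this assay compound 2 gives 100 mg/kg. Compound 3 `CC1(c2ccccc2)CC(=O)N(CC(=O)N2CCN(c3ccccc3Cl)CC2)C1=O` is the next member to be measured. It differs from compound 1 as follows: 2-chlorophenyl in place of 3-methylphenyl on an amine nitrogen in a ring. Within the data shown here, the series holds no measured pair that differs in one place, so no counted step is available to anchor the change. The expectation is a step in this assay of moderate size towards activity, that is, from an inactive result to a measurable dose in the region where compound 2 sits, though a further inactive outcome remains quite possible. For compound 3 in this assay the minimum effective dose is estimated at 150 mg/kg, with a range from 50 mg/kg to 400 mg/kg.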

Compound 3, minimum effective dose: "not active" (no number reported)
Compound 3: no number reported; the estimate stays without a comparison.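

In this assay, compound 1 gives "not active" (no number reported) and compound 3 gives "not active" (no number reported), so no step can be read between them. Nothing shown bears on this result. The compounds shown leave open whether any aryl group on this amine nitrogen in a ring can give a measurable minimum effective dose.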